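Swapping the halogenated ring on a shared quinazoline-free core

A few compounds are considered here, and "the series" means these few. Any claim that something is new, unique, unknown or untested is made for them only; others in the source may bear on it.

Of the compounds shown here, two of one series have been tested in a functional assay on MGC-803 cells (Homo sapiens) for cytotoxicity, read by MTT assay, with a stated time of 72 h; a lower number here means a stronger inhibitor, a higher number a weaker inhibitor. Compound 1 `CCCCCCCCCCCCCCNc1nc(SCc2ccc(C(F)(F)F)cc2)nc2ccccc12` carries a long straight alkyl chain on the ring nitrogen; in this assay compound 1 gives only > 50000 nM, a limit of the assay rather than a number, as shown by the limit of > 50000 nM in this assay, at which 1 of the 2 values shown sits. Compound 2 `FC(F)(F)c1ccc(CSc2nc(Nc3cccc(Br)c3)c3ccccc3n2)cc1` carries a 3-bromophenyl group on the same nitrogen, and in this assay compound 2 gives 23700 nM. Within the data shown here, compound 2 thus provides the only actual number in the set; the other value is a limit.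

Compound 3 `Fc1ccc(Nc2nc(SCc3ccc(C(F)(F)F)cc3)nc3ccccc23)cc1Cl` is the next compound, not yet measured. Its difference from compound 2 is 3-chloro-4-fluorophenyl in place of 3-bromophenyl on a nitrogen on an aromatic ring. Both groups are single halogenated carbon rings of almost the same size, with no hydrogen-bond donors or acceptors, so no step beyond the usual scatter is expected in this assay. Compound 3 is expected to give about 22000 nM, within a range from 8000 nM to 60000 nM. The step from compound 2 that this estimate means is a 1.1-fold lower number from compound 2 to compound 3 (0.03 log units; within the scatter), a change expected to stay within the scatter of repeated measurements.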

Compound 3, half-maximal inhibitory concentration: > 50000 nM
Compound 3: a limit, no number; the forecaster's own chance of this, stated with the estimate: 25%; middle value at least 2.2-fold (0.35 log units) away from the limit.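

Even a small change on this nitrogen can be read in the assay: 3-chloro-4-fluorophenyl in place of 3-bromophenyl gives an at least 2.1-fold higher number from compound 2 to compound 3 (0.32 log units; beyond the scatter), although each group is a single six-membered aromatic ring of carbon carrying halogen. Compound 3 gives > 50000 nM, which is a limit of the assay and not a number, so the true size of the step remains unknown and only its lower bound is shown. Compound 2 therefore remains the only compound here with a measured number, while compound 3 joins the long-chain compound 1 at the top of the range: the limit of > 50000 nM in this assay, at which 2 of the 3 values shown sit.

The change swaps one halogen for two different ones, so these compounds cannot show whether losing the bromine, adding the chlorine in its place, or adding the fluorine accounts for the step; 3-chlorophenyl and 4-fluorophenyl groups on the same nitrogen would separate these possibilities. From the compounds shown here alone, it also stays open whether a plain phenyl ring, or a ring carrying an amine or a carboxylic acid, would give a number well below that of compound 2.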